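The compounds below may be only part of what the source reports. "The series", "measured", "known", "first", "only" and "open" are said of these compounds alone.

Measured in a functional assay on A549 cells (Homo sapiens) for antiproliferative activity, read by XTT assay, with a stated time of 72 h; a higher number here means a weaker inhibitor, a lower number a stronger inhibitor:

Compound 1 `C=C(C)CCC[C@]1(C)C2=CCC[C@](C)(CC(=O)c3ccoc3)[C@H]2CC[C@H]1C`: > 100000 nM
Compound 2 `C=C(C)CC[C@]1(C)C2=CCC[C@](C)(C[C@H](O)c3ccoc3)[C@H]2CC[C@H]1C`: 34000 nM
Compound 3 `C=C(C)CCC[C@]1(C)C2=CCC[C@](C)(C[C@@H](OC(C)=O)C3=CC(=O)OC3O)[C@H]2CC[C@H]1C`: 3200 nM

Compound 1 gives only a limit of the assay, > 100000 nM, and not a number. That leaves two numerical values in this assay. Compound 2 has the higher of them, 34000 nM, making it the weaker inhibitor of the two. Compound 3 stands lower at 3200 nM, and this gap lies beyond the usual scatter.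

Compound 4 `C=C(C)CC[C@]1(C)C2=CCC[C@](C)(C[C@@H](O)C3=CC(=O)OC3O)[C@H]2CC[C@H]1C` has not yet been measured. It departs from compound 2 on a saturated chain carbon bound to a saturated ring carbon: a group of 9 heavy atoms (5 carbon, 4 oxygen; one five-membered non-aromatic ring with 1 hetero atom) in place of a group of 7 heavy atoms (5 carbon, 2 oxygen; one five-membered aromatic ring with 1 hetero atom), on a saturated chain carbon bound to a saturated ring carbon. The aromatic furan-bearing group is thus replaced by a larger group built on a non-aromatic five-membered ring.

Going by the values given here, no measured pair isolates this change, so any expectation rests on indirect evidence. Among the measured compounds, a non-aromatic five-membered ring with 1 hetero atom appears only in compound 3, at 3200 nM. On that single comparison, a lower number than that of compound 2 is expected, though this is a weak basis. The expected change is a 5.7-fold lower number from compound 2 to compound 4 (0.75 log units; beyond the scatter), a step toward stronger inhibition and beyond the scatter.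

For compound 4 the estimated value is 6000 nM, with an expected range from 1500 nM to 25000 nM.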

Compound 4, half-maximal inhibitory concentration: 4400 nM
Estimate against measurement, compound 4: 1.4-fold (0.13 log units) above; measured number inside the range.
By their numbers in this assay, from the lowest: compounds 3 and 4 (each within the scatter of the next); then compound 2. At a limit, above all of these: compound 1.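

In this assay, going by these compounds alone, replacing the (furan-3-yl)(hydroxy)methyl group with the larger group built on a five-membered non-aromatic ring gives a 7.7-fold lower number from compound 2 to compound 4 (0.89 log units; beyond the scatter), the first step in this set in which only one place changes. It shows that this place, a saturated chain carbon bound to a saturated ring carbon, responds to the group it carries while the rest of compound 2 stays the same; the non-aromatic ring had previously appeared only in compound 3, which differs from compound 2 in more than one place. The step itself gives no cause for the change, and the one further point on record concerns compound 1, whose entry is a limit and not a number: the limit of > 100000 nM in this assay, at which 1 of the 4 values shown sits.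

The compounds shown leave open which feature of the entering group carries the step, whether its additional oxygen atoms, its double bonds outside aromatic rings or the loss of the aromatic ring, since these all change together. They also do not show how a phenyl ring or a carboxylic acid at this place would read in this assay.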